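The source may hold more compounds than are shown below. What is called first, only, known or untested is meant among the compounds shown, and "the series" means these compounds.

Working notes on the benzyl ether series. Compound 1 `COc1cc(OC)c(-c2coc3cc(OCc4ccccc4F)ccc3c2=O)cc1OC` carries 2-fluorophenyl on the saturated chain carbon bound to the aromatic oxygen; in a functional assay on HUVEC cells (Homo sapiens) for antiproliferative activity, read by MTT assay, with a stated time of 24 h (a lower number here means a stronger inhibitor, a higher number a weaker inhibitor), compound 1 gives 4300 nM. Compound 2 `COc1cc(OC)c(-c2coc3cc(OCc4ccccc4C)ccc3c2=O)cc1OC` has methyl in place of fluoro there, and in this assay compound 2 gives 4830 nM, a step of a 1.1-fold higher number from compound 1 to compound 2 (0.05 log units; within the scatter). Compound 3 `COc1cc(OC)c(-c2coc3cc(OCc4ccc([N+](=O)[O-])cc4)ccc3c2=O)cc1OC` carries 4-nitrophenyl at the same place. In this assay compound 3 reaches only the limit of the assay, > 10000 nM, so no number is known for it (the limit of > 10000 nM in this assay, at which 1 of the 3 values shown sits). Both measured steps into compound 3 run toward weaker inhibition: an at least 2.3-fold higher number from compound 1 to compound 3 (0.36 log units; beyond the scatter) and an at least 2.0-fold higher number from compound 2 to compound 3 (0.31 log units; beyond the scatter).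

Compound 4 `COc1cc(OC)c(-c2coc3cc(OCc4cccc(C(F)(F)F)c4)ccc3c2=O)cc1OC` is the next step from compound 3: 3-(trifluoromethyl)phenyl in place of 4-nitrophenyl on a saturated chain carbon bound to an oxygen on an aromatic ring. For the measured compounds named here, the two measured steps show that changing the aryl part of the benzyl group can move the number beyond the scatter, and the 4-nitrophenyl group that gives the limit leaves here; no trifluoromethyl analogue has been measured, so the direction rests on that alone. Compound 4 is therefore expected to give about 6000 nM, between 2500 nM and 15000 nM. The expected step is an at least 1.6-fold lower number from compound 3 to compound 4 (0.22 log units; that floor lies within the scatter).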

Compound 4, half-maximal inhibitory concentration: > 10000 nM
Compound 4: a limit, no number (the forecaster's own chance of this, stated with the estimate: 30%); middle value at least 1.6-fold (0.22 log units) away from the limit.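

At this place, on a saturated chain carbon bound to an oxygen on an aromatic ring, the limit in this assay no longer belongs to 4-nitrophenyl alone, since 3-(trifluoromethyl)phenyl, which has no hydrogen-bond acceptors, ends there too: the limit of > 10000 nM in this assay, at which 2 of the 4 values shown sit. Measured against the compounds that still give a number, the change reads as an at least 2.0-fold higher number from compound 2 to compound 4 (0.31 log units; beyond the scatter) and as an at least 2.3-fold higher number from compound 1 to compound 4 (0.36 log units; beyond the scatter), and both are floors rather than sizes. The step between compound 3 and compound 4 cannot be read, so these two groups cannot be ranked.

Still open, from the compounds shown here alone, is whether 2-fluorophenyl and 2-methylphenyl keep a number through the place of their substituent or through the substituent itself. Also open, going by these compounds, is what a benzyl group bearing an amine or a carboxylic acid would give.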